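The source may hold more compounds than are shown below. What is called first, only, known or untested is meant among the compounds shown, and "the series" means these compounds.

Measured compounds in the series:

Compound 1, `Cc1cc(C)c2c(O)cc(-c3cccc(F)c3)nc2n1`, in a functional assay on cells (Tumor Cell line, Homo sapiens) for antiproliferative activity (on this read-out higher numbers stand for weaker inhibition of growth and lower numbers for stronger inhibition of growth), compound 1 gives 85.1 nM.
Compound 2, `Cc1cc(C)c2c(O)cc(-c3cccc(Cl)c3)nc2n1`, in this assay compound 2 gives 347 nM.
Compound 3, `Cc1cnc2[nH]c(-c3cccc(Cl)c3)cc(=O)c2c1`, in this assay compound 3 gives 269 nM.

Compounds 1 and 2 share one core and differ only in the halogen on the pendant aryl ring; the change is fluoro in place of chloro on an aromatic carbon. In this assay this gave a 4.1-fold lower number from compound 2 to compound 1 (0.61 log units; beyond the scatter), a step beyond the scatter of the read-out.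

Compound 3 carries a different core with the same chloro-substituted aryl ring. The difference between the two cores is not broken down here. Against compound 2 the value of compound 3 lies within the scatter; against compound 1 it lies beyond it.

Compound 4, `Cc1cnc2[nH]c(-c3cccc(F)c3)cc(=O)c2c1`, is the fluoro partner of compound 3 on that second core. The change from compound 3 to compound 4 is fluoro in place of chloro on an aromatic carbon, and its place is described in the same words as for the change from compound 2 to compound 1, so it is taken as the same change, made once already among the measured compounds. Going by the values given here, the expectation in this assay is a step of about a 3.2-fold lower number from compound 3 to compound 4 (0.50 log units; beyond the scatter), resting on the single earlier step of a 4.1-fold lower number from compound 2 to compound 1 (0.61 log units; beyond the scatter); with only one precedent, and on a different core, the range is kept wide. Compound 4 is therefore estimated at 85 nM, between 35 nM and 220 nM.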

Compound 4, concentration for 50% growth inhibition: 50.1 nM
Compound 4: middle estimate off by 1.7-fold (0.23 log units), on the high side, and the stated range covers the measured number.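

In this assay, fluoro in place of chloro on an aromatic carbon gave a 5.4-fold lower number from compound 3 to compound 4 (0.73 log units; beyond the scatter), so the step seen on the core of compound 1 recurs on the core of compound 3 in direction and, within the scatter, in size: the same change on two cores in this assay, a 4.1-fold lower number (0.61 log units; beyond the scatter) from compound 2 to compound 1 and a 5.4-fold lower number (0.73 log units; beyond the scatter) from compound 3 to compound 4, 1.3-fold (0.12 log units) apart, within the scatter of two such steps. Across these two cores, the change can therefore be carried over as a step of similar size, with the fluoro compound giving the lower number in each pair. The support is limited to two matched pairs, one place on the aryl ring and one read-out, so this does not show that the step would hold on a further core or at another place on the ring, and it gives no reason for the size of the step.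

The compounds shown leave open whether the lower number is particular to fluoro or extends to other groups at the same place, such as methoxy, a nitrile or an amine. Going by these compounds, the contribution of the core itself also remains open, since compound 1 and compound 4 differ in more than one place and their values do not form a clean step.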